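Aryl swap on the hydrazone: toward compound 3

The compounds below may be only part of what the source reports. "The series", "measured", "known", "first", "only" and "open" are said of these compounds alone.

Compound 1 `COc1ccc(/C=N/NC(=O)CSc2nnnn2-c2cccc3ccccc23)c(OC)c1`: 28300 nM
Compound 2 `COc1ccc(/C=N/NC(=O)CSc2nnnn2-c2cccc3ccccc23)cc1OC`: 191000 nM

Going by the values given here, in an ADME assay on MT4 cells (Homo sapiens) for cytotoxicity, read by MTT assay (on this read-out lower numbers stand for higher toxicity in this test and higher numbers for lower toxicity in this test), compound 2 gives the higher of the two numbers; the single step of a 6.7-fold higher number from compound 1 to compound 2 (0.83 log units; beyond the scatter) shows that rearranging the methoxy groups alone moves this read-out. Compound 3 `O=C(CSc1nnnn1-c1cccc2ccccc12)N/N=C/c1ccccc1O` differs from compound 2 by 2-hydroxyphenyl in place of 3,4-dimethoxyphenyl on a carbon with a double bond to nitrogen. Among the compounds with values here, no measured step bears directly on trading the dimethoxy pattern for a hydroxyl, so the direction is open; the one step seen says only that the aryl part matters. A modest drift back toward compound 1 is expected, a 3.2-fold lower number from compound 2 to compound 3 (0.50 log units; beyond the scatter). For compound 3 the estimate is 60000 nM, with a range of 15000 nM to 250000 nM.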

Compound 3, half-maximal cytotoxic concentration: 4850 nM
Estimate against measurement, compound 3: 12-fold (1.09 log units) above, and the stated range ends above it.
By their numbers in this assay, from the lowest: compound 3; then compound 1; then compound 2.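

In this assay, the aryl group on the carbon with a double bond to nitrogen spans a wider range than the methoxy rearrangement alone showed: 2-hydroxyphenyl in place of 3,4-dimethoxyphenyl gives the larger step (a 39-fold lower number from compound 2 to compound 3 (1.60 log units; beyond the scatter)), and in place of 2,4-dimethoxyphenyl a smaller one (a 5.8-fold lower number from compound 1 to compound 3 (0.77 log units; beyond the scatter)). The number falls against both dimethoxyphenyl compounds, so this change does not depend on which methoxy pattern leaves. Nothing available explains the shift.

The hydroxyl and the loss of the methoxy groups cannot be separated here, since compound 3 differs in both. On these data alone, how an aryl group bearing an amine or a carboxylic acid would read remains open.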